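Compound 4: swapping acetoxymethyl for cyclohexyl

The compounds below may be only part of what the source reports. "The series", "measured", "known", "first", "only" and "open" are said of these compounds alone.

- compound 1 `O=CCc1c(-c2ccccc2Cl)c2cc(Cl)ccc2[nH]c1=O` gives 120000 nM here
- compound 2 `CC(C)C(=O)OCCc1c(-c2ccccc2Cl)c2cc(Cl)ccc2[nH]c1=O` gives 62000 nM here
- compound 3 `CC(=O)OCC(=O)OCCc1c(-c2ccccc2Cl)c2cc(Cl)ccc2[nH]c1=O` gives 100000 nM here

These values come from an ADME assay on HepG2 2.2.15 cells (Homo sapiens) for cytotoxicity (a higher number here means that more compound is tolerated, a lower number that less compound is tolerated), and they lie close together. The data show a 1.2-fold lower number from compound 1 to compound 3 (0.08 log units; within the scatter) and also a 1.6-fold higher number from compound 2 to compound 3 (0.21 log units; within the scatter) so compound 3 cannot be separated from either neighbour. The remaining pair shows a 1.9-fold lower number from compound 1 to compound 2 (0.29 log units; within the scatter) as well.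

Compound 4 `O=C(OCCc1c(-c2ccccc2Cl)c2cc(Cl)ccc2[nH]c1=O)C1CCCCC1` keeps the shared core and changes one group of compound 3, with cyclohexyl in place of acetoxymethyl on a carbonyl carbon as the whole difference. The incoming group is one six-membered non-aromatic ring of carbon only.

The closest guide is compound 2, which carries isopropyl on that same carbonyl carbon and gives 62000 nM in this assay as its result. Isopropyl is not cyclohexyl, so this guide is only partial, and no measured compound carries a ring there. The expected change is modest, a move toward compound 2, and the estimate is a 1.8-fold lower number from compound 3 to compound 4 (0.26 log units; within the scatter) with nothing expected beyond the scatter. For compound 4 the estimated value is 55000 nM with an expected range from 22000 nM to 120000 nM in this assay once it is measured.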

Compound 4, half-maximal cytotoxic concentration: 38000 nM
For compound 4 the middle estimate is 1.4-fold (0.16 log units) above the measured one, within the range that was stated.
By their numbers in this assay, from the lowest: compounds 4, 2, 3 and 1 (each within the scatter of the next, the first and the last beyond it).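

In this assay, for the compounds shown here, changing the group on this carbonyl carbon now produces a step beyond the scatter, though a modest one (a 2.6-fold lower number from compound 3 to compound 4 (0.42 log units; beyond the scatter)), something no earlier pair showed; the step to the formyl compound is also modest and beyond the scatter (a 3.2-fold lower number from compound 1 to compound 4 (0.50 log units; beyond the scatter)). Cyclohexyl and isopropyl at this place cannot be separated (a 1.6-fold lower number from compound 2 to compound 4 (0.21 log units; within the scatter)), so compound 2 overlaps with both compound 3 and compound 4, even though those two differ from each other. Nothing measured here explains why the cyclohexyl compound stands apart from compound 1 and compound 3.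

From the compounds shown here alone, it remains open whether a smaller ring such as cyclopropyl, or an aromatic ring such as phenyl, would behave like cyclohexyl at this carbonyl carbon. The same question applies to a longer straight carbon chain or a group carrying an amine.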